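The source may hold more compounds than are shown below. What is called first, only, known or untested is meant among the compounds shown, and "the series" means these compounds.

Measured so far:
compound 1 `C=CC(=O)Oc1cc(C(F)(F)F)cc(C(F)(F)F)c1`: < 0.017 h
compound 2 `C#Cc1cc(C(F)(F)F)cc(C(F)(F)F)c1`: 2.4 h
compound 3 `N#Cc1cc(C(F)(F)F)cc(C(F)(F)F)c1`: > 50 h

All three share one core and differ only in the group on the ring. In an ADME assay for pharmacokinetics, read by HPLC, in phosphate buffer, with a stated time of 72 h, at pH 7.4, tested at 250 uM (a higher number here means that the compound lasts longer, a lower number that the compound disappears faster), compound 1 reaches only a limit of the assay, (the limit of < 0.017 h in this assay, at which 1 of the 3 values shown sits). Compound 2 gives a number, 2.4 h. For compound 3 the assay again reports only a limit, (the limit of > 50 h in this assay, at which 1 of the 3 values shown sits), so compound 3 stands at the long-lived end of what this assay can show, above the other two values.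

Compound 4 `Fc1cc(C(F)(F)F)cc(C(F)(F)F)c1` differs from compound 3 by fluoro in place of cyano on an aromatic carbon. The measured steps all point one way: an at least 140-fold higher number from compound 1 to compound 2 (2.14 log units; beyond the scatter), an at least 2900-fold higher number from compound 1 to compound 3 (3.46 log units; beyond the scatter) and an at least 20-fold higher number from compound 2 to compound 3 (1.31 log units; beyond the scatter). Both steps that end in compound 3 are large and reach the limit. Nothing here says what happens when the cyano group is exchanged for fluoro, so the expectation is that compound 4 again reaches the limit and that a step that the limit leaves unreadable from compound 3 to compound 4 is the estimated step, not beyond the scatter. Compound 4 is therefore expected to give 80 h, between 25 h and 300 h.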

Compound 4, half-life: > 50 h
Compound 4: a limit, no number (the forecaster's own chance of this, stated with the estimate: 70%); the middle value does not contradict the limit.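

Compound 4 also reaches a limit of this assay: the limit of > 50 h in this assay, at which 2 of the 4 values shown sit. At this position, on an aromatic carbon meta to two trifluoromethyl groups, fluoro carries no triple bond and still gives a large step up, with an at least 20-fold higher number from compound 2 to compound 4 (1.31 log units; beyond the scatter) and an at least 2900-fold higher number from compound 1 to compound 4 (3.46 log units; beyond the scatter), so a triple bond is not needed to reach the long-lived end. With two limits, the step from compound 3 to compound 4 cannot be read, so no order between cyano and fluoro can be stated.

Going by these compounds, how much longer than the limit compound 3 and compound 4 last remains unknown. Also open, on these data alone, is whether an amine, a carboxylic acid or a longer chain at this position would stay at the limit or fall toward the number given by compound 2.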